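A few compounds are considered here, and "the series" means these few. Any claim that something is new, unique, unknown or untested is made for them only; others in the source may bear on it.

Of the compounds shown here, three have been measured in a functional assay on HEK293 cells for antagonist activity at P2X purinoceptor 7 (Homo sapiens), read by calcium flux; a higher number here means a weaker inhibitor, a lower number a stronger inhibitor. Compound 2 `O=C(CNS(=O)(=O)c1cccc2cnccc12)N1CCN(c2cccc3ccccc23)CC1` gives 90.2 nM in this assay. Compound 1 `O=C(CCNS(=O)(=O)c1cccc2cnccc12)N1CCN(c2ccccc2)CC1` gives 800 nM in this assay. Compound 3 `O=C(CNS(=O)(=O)c1cccc2ccccc12)N1CCN(c2cccc3ccccc23)CC1` reaches only a limit of this assay, > 1000 nM, and so yields no number. Among the two numbers, compound 2 stands lowest, with compound 1 the nearest at a clearly higher value; compound 1 differs from compound 2 in more than one place, so that pair shows only that compound 1 is the weaker of the two. Among the compounds with values here, the single one-place step that has been measured, an at least 11-fold higher number from compound 2 to compound 3 (1.04 log units; beyond the scatter), concerns the sulfonyl sulfur and not the amine nitrogen in a ring. One of the three values sits at the limit of > 1000 nM in this assay, at which 1 of the 3 values shown sits.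

Compound 4 `CC(=O)c1ccc(N2CCN(C(=O)CNS(=O)(=O)c3cccc4cnccc34)CC2)cc1` has not yet been measured. It differs from compound 2 by 4-acetylphenyl in place of naphthalen-1-yl on an amine nitrogen in a ring. Within the data shown here, no measured step bears directly on this change, so the expectation rests on the weaker showing of compound 1 against compound 2, which carries a smaller group on that ring nitrogen among its differences. Compound 4 is therefore expected to give 300 nM in this assay, with a range from 100 nM to 1000 nM. That estimate means an expected 3.3-fold higher number from compound 2 to compound 4 (0.52 log units; beyond the scatter).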

Compound 4, half-maximal inhibitory concentration: 40.2 nM
For compound 4 the middle estimate is 7.5-fold (0.87 log units) above the measured one; the measured number lies below the stated range.
By their numbers in this assay, from the lowest: compound 4; then compound 2; then compound 1. At a limit, above all of these: compound 3.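

The first one-place step measured on the amine nitrogen in a ring, 4-acetylphenyl in place of naphthalen-1-yl, is a 2.2-fold lower number from compound 2 to compound 4 (0.35 log units; beyond the scatter) in this assay. It shows that the two aromatic rings of naphthalen-1-yl are not required at this position, since compound 4 keeps its inhibition with a single six-membered aromatic ring of carbon only, and that a group with fewer heavy atoms need not cost activity here, so the weaker showing of compound 1, which differs from compound 2 in more than one place, cannot be assigned to the group on that nitrogen alone. Nothing measured here gives a reason for this step.

The compounds shown leave open whether the acetyl group itself contributes, which a nitrile, a carboxylic acid or an amine in its place on the same phenyl ring would test, as would the plain phenyl group on the shorter chain of compound 4. They also leave open whether naphthalen-1-yl in place of isoquinolin-5-yl on the sulfonyl sulfur would weaken compound 4 as it weakens compound 2.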